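Solubility notes: a urea analogue in the piperidine amide series

The compounds below may be only part of what the source reports. "The series", "measured", "known", "first", "only" and "open" are said of these compounds alone.

Compound 3 `CC(C)(C)c1cc(NC(=O)[C@@H]2CCCCN2C(=O)CC2CCOCC2)no1` gives 52 ug/mL in a physicochemical assay for solubility, read by HPLC, at pH 6.8; on this read-out higher numbers stand for higher solubility and lower numbers for lower solubility. Among the compounds with a number, compound 3 stands lowest of two; its nearest neighbour, compound 1 `CC(C)(C)c1cc(NC(=O)[C@@H]2CCCCN2C2CCOCC2)no1`, gives 74 ug/mL, and the step of a 1.4-fold lower number from compound 1 to compound 3 (0.15 log units; within the scatter) lies within the scatter. Compound 2 `CC(C)(C)c1cc(NC(=O)[C@@H]2CCCCN2C(=O)c2ccc(Cl)cc2)no1` returns only a limit, < 0.1 ug/mL, in this assay. Compound 4 `CC(C)(C)c1cc(NC(=O)[C@@H]2CCCCN2C(=O)N2CC[S+]([O-])CC2)no1` differs from compound 3 by a group of 7 heavy atoms (4 carbon, 1 nitrogen, 1 oxygen, 1 sulfur; one six-membered non-aromatic ring with 2 hetero atoms) in place of a group of 7 heavy atoms (6 carbon, 1 oxygen; one six-membered non-aromatic ring with 1 hetero atom), on a carbonyl carbon.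

Going by the values given here, two measured steps touch the same carbonyl carbon. The step of an at least 520-fold higher number from compound 2 to compound 3 (2.71 log units; beyond the scatter) shows that what sits on that carbonyl carbon can move this read-out a long way, with the limit of compound 2 at the bottom (the limit of < 0.1 ug/mL in this assay, at which 1 of the 3 values shown sits). The step of a 1.4-fold lower number from compound 1 to compound 3 (0.15 log units; within the scatter) shows that exchanging one saturated oxygen-containing ring attachment for another at the ring nitrogen leaves this assay unchanged within the scatter. Compound 4 keeps a six-membered non-aromatic ring on that carbonyl carbon, so for compound 4 a step of a 1.3-fold higher number from compound 3 to compound 4 (0.13 log units; within the scatter) is expected, within the scatter of compound 3. Compound 4 is thus estimated at 70 ug/mL, with a range from 25 ug/mL to 200 ug/mL.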

Compound 4, solubility: 68 ug/mL
Beside the measured number, compound 4's estimate is 1.0-fold (0.01 log units) above it; low and high end bracket the measured number.
By their numbers in this assay, from the lowest: compounds 3, 4 and 1 (each within the scatter of the next). At a limit, below all of these: compound 2.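

On a carbonyl carbon whose other neighbours are an amide-type nitrogen in a ring, the group with a six-membered non-aromatic ring holding 2 hetero atoms leaves this assay within the scatter of (oxan-4-yl)methyl, a 1.3-fold higher number from compound 3 to compound 4 (0.12 log units; within the scatter), and the comparison with the oxan-4-yl compound also stays within the scatter, a 1.1-fold lower number from compound 1 to compound 4 (0.04 log units; within the scatter). Set against the (4-chlorophenyl)carbonyl compound, the new sulfur-containing ring gives a second large step, an at least 680-fold higher number from compound 2 to compound 4 (2.83 log units; beyond the scatter). Compound 2 stands at a limit and not at a number: the limit of < 0.1 ug/mL in this assay, at which 1 of the 4 values shown sits.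

Still open, from the compounds shown here alone, is whether plain phenyl on that carbonyl carbon, without the chlorine, would also fall to a limit. Also open, going by these compounds, is whether an open-chain amine there would stay within the scatter of compound 4.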